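A few compounds are considered here, and "the series" means these few. Any claim that something is new, unique, unknown or untested is made for them only; others in the source may bear on it.

Measured so far in an ADME assay on microsomes from liver (Rattus norvegicus) for metabolic stability; on this read-out higher numbers stand for a longer-lived compound and lower numbers for a shorter-lived compound:
compound 1 `CCC(/C=C1\OC(=O)NC1=O)(CC)c1ccc(-c2ccc3cc(F)cc(F)c3c2)[nH]c1=O` — > 3 h
compound 2 `CC(C)/C(=C1\C(=O)NC(=O)N1C)c1ccc(-c2ccc3cccc(F)c3c2)[nH]c1=O` — > 3 h
compound 3 `Cc1cc(C(/C=C2\OC(=O)NC2=O)C(C)C)c(=O)[nH]c1-c1ccc2cccc(F)c2c1` — > 3 h

Each of these three values is a limit of this assay and not a number. For compound 1 the read-out stops at the limit; the same holds for compound 2, and for compound 3. Compound 1 therefore stands level with the other two on the numbers shown, and nothing separates the three, since all of them sit at the limit of > 3 h in this assay, at which 3 of the 3 values shown sit. Among the compounds with values here, no step between measured compounds can be sized in this assay, because every value shown rests on (the limit of > 3 h in this assay, at which 3 of the 3 values shown sit).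

Compound 4 `CCC(/C=C1\OC(=O)NC1=O)(CC)c1ccc(-c2ccc3cccc(F)c3c2)[nH]c1=O` is the next compound of the series to go into this assay. It differs from compound 1 in one place: hydrogen in place of fluoro on an aromatic carbon. The fluoro that leaves sits on the six-membered aromatic ring of carbon only within the fused system of two rings, meta to the remaining fluoro group; a hydrogen atom enters in its place.

Within the data shown here, with no measured step to lean on, the expectation for the step from compound 1 to compound 4 in this assay is none beyond the scatter, a number no higher from compound 1 to compound 4 (the limit leaves the size open), in no fixed direction. Compound 4 is expected to give 3 h in this assay, within 1.5 h to 6 h, and most probably the read-out will again be reported only as a limit.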

Compound 4, half-life: > 3 h
Compound 4 ended at the assay's limit; the forecaster's own chance of this, stated with the estimate: 70%; the middle value sits exactly at the limit.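

In this assay compound 4 gives > 3 h, a limit and not a number. Compound 1 gives > 3 h, also a limit, so the swap of fluoro for hydrogen linking compound 1 and compound 4 yields no readable step. The compounds shown leave open how their half-lives actually differ, as every value rests on one limit: the limit of > 3 h in this assay, at which 4 of the 4 values shown sit.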